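The source may report more compounds than this note shows. Statements on the series, on what has been measured and on what is new or still open speak of the compounds shown alone.

Working notes on the series. Within the data shown here, in a functional assay on the whole organism for inhibition, with Mus musculus as the target (on this read-out lower numbers stand for an effect already at smaller amounts and higher numbers for an effect only at larger amounts of compound), compound 1 `COC(=O)NC1=NC(c2c(Cl)cccc2Cl)CN1` gives 14.2 mg/kg, the lowest of the two numbers available so far. Among the measured compounds shown here, the only other measured compound, compound 2 `CCOC(=O)NC1=NC(c2ccccc2Cl)CN1C`, gives 34 mg/kg, a higher number by a margin beyond the usual scatter. These two compounds differ in more than one place, so their values offer no clean measure of any single change.

The next compound is compound 3 `NC1=NC(c2c(Cl)cccc2Cl)CN1`. It has hydrogen in place of methoxycarbonyl on an amine nitrogen, and the rest of the core of compound 1 is unchanged: hydrogen in place of methoxycarbonyl on an amine nitrogen. The same difference, cut one bond further out, reads (methoxycarbonyl)amino to amino.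

For the measured compounds named here, no measured pair isolates this change, so the expectation rests on the value of compound 1 alone and remains loose. In this assay, the expected outcome is no step beyond the scatter, with a slight lean towards a lower number: a 1.3-fold lower number from compound 1 to compound 3 (0.11 log units; within the scatter). For compound 3 the estimated value is 11 mg/kg, with an expected range from 2.5 mg/kg to 45 mg/kg.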

Compound 3, dose for half-maximal effect: 6.5 mg/kg
For compound 3 the middle estimate is 1.7-fold (0.23 log units) above the measured one; low and high end bracket the measured number.
By their numbers in this assay, from the lowest: compound 3; then compound 1; then compound 2.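

In this assay, among these compounds, replacing methoxycarbonyl with hydrogen on this amine nitrogen gives a 2.2-fold lower number from compound 1 to compound 3 (0.34 log units; beyond the scatter) and provides the first comparison that isolates a single change. The result shows that, on the core of compound 1, the methoxycarbonyl group is not required for an effect in the whole organism, since the simple amino compound 3 reaches a lower dose, although the step is only modest. No supporting measurement is available to explain the step, so it stands here as an observed difference only.

This single pair cannot show whether any substituent on this amine nitrogen would raise the number or whether the step is specific to methoxycarbonyl, and an acetyl group or a benzyl group at the same place would help separate these two readings. It also leaves open whether the step carries over to other parts of the series, including a core with a single chlorine on the aryl group or a methyl group on the other ring nitrogen, as in compound 2, which differs from compound 1 and compound 3 in more than one place.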